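A few compounds are considered here, and "the series" means these few. Any claim that something is new, unique, unknown or untested is made for them only; others in the source may bear on it.

Compound 3 `CCCNC(=O)c1cc(Oc2ccc(NC(=O)c3cc4cccnc4n(-c4ccc(OC)cc4)c3=O)cc2)ccn1` belongs to a short series built on one shared core, and in a functional assay on HT-29 cells (Homo sapiens) for antiproliferative activity, read by MTT assay, with a stated time of 72 h (a higher number here means a weaker inhibitor, a lower number a stronger inhibitor), compound 3 gives 1560 nM. Of the three numbers seen so far this is the second highest: compound 1 `CCNC(=O)c1cc(Oc2ccc(NC(=O)c3cc4cccnc4n(-c4ccc(Br)cc4F)c3=O)cc2)ccn1` gives 2070 nM in this assay, which lies within the scatter of compound 3, while compound 2 `CCCNC(=O)c1cc(Oc2ccc(NC(=O)c3cc4cccnc4n(-c4ccc(F)cc4)c3=O)cc2)ccn1` gives 84 nM, and the step of a 19-fold higher number from compound 2 to compound 3 (1.27 log units; beyond the scatter) is large and well beyond the scatter.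

Compound 4 `CCCNC(=O)c1cc(Oc2ccc(NC(=O)c3cc4cccnc4n(-c4ccc(Br)cc4F)c3=O)cc2)ccn1` has not yet been measured. It differs from compound 3 in one place: 4-bromo-2-fluorophenyl in place of 4-methoxyphenyl on an aromatic nitrogen. For the measured compounds named here, no measured step reproduces this exact exchange. Going by the values given here, the only step that bears on this position is the one from compound 2 to compound 3, which shows that a change of the group on the aromatic nitrogen can move the number a great deal. The same 4-bromo-2-fluorophenyl that enters in compound 4 is carried by compound 1, with an ethyl amide rather than a propyl amide, and compound 1 gives 2070 nM, a number that sits close to that of compound 3. On that basis compound 4 is expected to give about 1800 nM in this assay, with a plausible range from 500 nM to 6500 nM, so that the expected step of a 1.2-fold higher number from compound 3 to compound 4 (0.06 log units; within the scatter) stays within the scatter.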

Compound 4, half-maximal inhibitory concentration: 2160 nM
Compound 4: middle estimate off by 1.2-fold (0.08 log units), on the low side; the measured number falls inside the stated range.
By their numbers in this assay, from the lowest: compound 2; then compounds 3, 1 and 4 (each within the scatter of the next).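

Compound 4 shows that at this position the exchange of 4-methoxyphenyl for 4-bromo-2-fluorophenyl on the aromatic nitrogen leaves the number in this assay within the scatter, with a 1.4-fold higher number from compound 3 to compound 4 (0.14 log units; within the scatter) as the step, even though the two groups carry different substituents. The step of a 26-fold higher number from compound 2 to compound 4 (1.41 log units; beyond the scatter) is large, and together with the step of a 19-fold higher number from compound 2 to compound 3 (1.27 log units; beyond the scatter) it sets the 4-fluorophenyl of compound 2 apart from both of the other groups at this position. The step of a 1.0-fold higher number from compound 1 to compound 4 (0.02 log units; within the scatter) adds that, with 4-bromo-2-fluorophenyl in place, the added methyl that turns the ethyl amide into the propyl amide makes no difference beyond the scatter.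

The compounds shown leave open how a plain phenyl, a 4-chlorophenyl or a 2-fluorophenyl would fall on the aromatic nitrogen, and so which part of 4-bromo-2-fluorophenyl separates it from 4-fluorophenyl. They also leave open whether a longer chain or a terminal amine on the amide would move the number, and whether 4-fluorophenyl would keep its low number with an ethyl amide. No measurement offered here accounts for why 4-fluorophenyl stands apart at this position.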